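From a Methylpyrazole to a Pyridine on a Shared Core

The compounds below may be only part of what the source reports. "The series", "measured", "known", "first", "only" and "open" are said of these compounds alone.

Compound 1 `Cc1c(C(C)n2cnc3ncc(-c4cnn(C)c4)nc32)ccc2ncccc12` gives 206 nM here
Compound 2 `Cn1cc(-c2cnc3nc(O)n(Cc4ccc5ncccc5c4)c3n2)cn1` gives > 10000 nM as a limit
Compound 3 `CCC(c1ccc2ncccc2c1F)n1cnc2ncc(-c3cnn(CCO)c3)nc21` gives "not determined" (no result reported) here

The three compounds were tested in a functional assay on NCI-H1993 cells (Homo sapiens) for inhibition, read by CCK-8 assay, with a stated time of 72 h (on this read-out lower numbers stand for stronger inhibition and higher numbers for weaker inhibition), and only one of them has an exact reading. In this assay compound 1 gives 206 nM and is thus the sole firm reference point in this small set. Compound 2 gives > 10000 nM and this is a limit of the assay, not a number. For compound 3 the record reads "not determined" (no result reported) and so it offers no comparison.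

The next compound to be measured is compound 4 `Cc1c(C(C)n2cnc3ncc(-c4ccncc4)nc32)ccc2ncccc12` which carries pyridin-4-yl in place of 1-methyl-1H-pyrazol-4-yl on an aromatic carbon while the rest of compound 1 stays unchanged. Within the data shown here, no measured pair in this set differs in one place only, so no direct precedent exists for this swap, and the expectation rests on compound 1 and the structural change alone. A modest weakening in this assay is expected, with the estimated change being a 2.4-fold higher number from compound 1 to compound 4 (0.39 log units; beyond the scatter) in this read-out. For compound 4 the estimated value is 500 nM in this measurement. The expected range for compound 4 runs from 130 nM to 1800 nM on this estimate.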

Compound 4, half-maximal inhibitory concentration: 950 nM
Beside the measured number, compound 4's estimate is 1.9-fold (0.28 log units) below it; low and high end bracket the measured number.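

In this assay, among these compounds, the exchange of 1-methyl-1H-pyrazol-4-yl for pyridin-4-yl gives the first direct reading of a change at this aromatic carbon, with a 4.6-fold higher number from compound 1 to compound 4 (0.66 log units; beyond the scatter). On the core of compound 1, this position therefore responds to the replacement of a five-membered aromatic ring with 2 hetero atoms by a six-membered aromatic ring with 1 hetero atom, although compound 4 still gives an exact reading and not a limit. The measured values give no reason for this step, which this single pair records only as a change in the read-out.

The compounds shown leave open how a phenyl ring, with no ring nitrogen, or an amine at this same carbon would read in this assay. A single pair also cannot tell whether the step belongs to the change of ring size, the number of ring nitrogens or the loss of the methyl group, and a pyrazole carrying a longer chain would be needed to begin separating these.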